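The source may hold more compounds than are shown below. What is called first, only, known or untested is meant among the compounds shown, and "the series" means these compounds.

Compound 1 `O=C1N=C(N2CCC[C@H]2C(=O)Nc2ccc3ncnc(Nc4cccc(Cl)c4)c3c2)S/C1=C/c1ccccc1F` — 18200 nM
Compound 2 `O=C1N=C(N2CCC[C@H]2C(=O)Nc2ccc3ncnc(Nc4cccc(Cl)c4)c3c2)S/C1=C/c1ccccc1[N+](=O)[O-]` — 32500 nM
Compound 3 `O=C1N=C(N2CCC[C@H]2C(=O)Nc2ccc3ncnc(Nc4cccc(Cl)c4)c3c2)S/C1=C/c1ccc(-c2ccccc2)cc1` — 15400 nM

Three compounds share one core and differ only in the aryl group on the double-bonded chain carbon. In a functional assay on HepG2 cells (Homo sapiens) for antiproliferative activity, read by MTT assay (a lower number here means a stronger inhibitor, a higher number a weaker inhibitor), compound 1 gives 18200 nM, the second highest of the three numbers; compound 3 gives 15400 nM and compound 2 gives 32500 nM. The steps between them are small: a 1.8-fold higher number from compound 1 to compound 2 (0.25 log units; within the scatter) and a 1.2-fold lower number from compound 1 to compound 3 (0.07 log units; within the scatter), while a 2.1-fold lower number from compound 2 to compound 3 (0.32 log units; beyond the scatter).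

Compound 4 `O=C1N=C(N2CCC[C@H]2C(=O)Nc2ccc3ncnc(Nc4cccc(Cl)c4)c3c2)S/C1=C/c1ccccc1Cl` differs from compound 1 in one place: chloro in place of fluoro on an aromatic carbon. Within the data shown here, the one measured step that touches the same position is the one where nitro replaced this fluoro, and it gave a 1.8-fold higher number from compound 1 to compound 2 (0.25 log units; within the scatter). Swapping the whole aryl group for 4-phenylphenyl also gave a 1.2-fold lower number from compound 1 to compound 3 (0.07 log units; within the scatter). Since every change at this end of the molecule has stayed within or barely beyond the scatter, no step beyond the scatter is expected in this assay for chloro in place of fluoro either. Compound 4 is therefore estimated at 16000 nM, in the range 8000 nM to 32000 nM, meaning an expected 1.1-fold lower number from compound 1 to compound 4 (0.06 log units; within the scatter).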

Compound 4, half-maximal inhibitory concentration: 28100 nM
For compound 4 the middle estimate is 1.8-fold (0.24 log units) below the measured one; the measured number falls inside the stated range.
By their numbers in this assay, from the lowest: compounds 3, 1, 4 and 2 (each within the scatter of the next, the first and the last beyond it).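

In this assay, chloro in place of fluoro on this aromatic carbon gives a 1.5-fold higher number from compound 1 to compound 4 (0.19 log units; within the scatter), so exchanging one of these halogens for the other leaves the number within the scatter. Compound 4 also stays within the scatter of both other compounds, with a 1.2-fold lower number from compound 2 to compound 4 (0.06 log units; within the scatter) for chloro in place of nitro and a 1.8-fold higher number from compound 3 to compound 4 (0.26 log units; within the scatter) for 2-chlorophenyl in place of 4-phenylphenyl, so chloro cannot be told apart from fluoro or nitro at this place, nor from the larger aryl change. Nothing measured here offers an explanation for these small steps.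

The compounds shown leave open how an amine or a carboxylic acid on this same aromatic carbon would read in this assay. They also leave open whether any group here could bring the number far below those seen so far.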